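Moving a methoxy group on a cytotoxic compound

The source may hold more compounds than are shown below. What is called first, only, known or untested is meant among the compounds shown, and "the series" means these compounds.

In a functional assay on A549 cells (Homo sapiens) for cytotoxicity, read by MTT assay, with a stated time of 72 h (on this read-out lower numbers stand for stronger inhibition and higher numbers for weaker inhibition), compound 1 `COc1ccc(/C=C2\CCC/C(=C\c3ccccc3Br)C2=O)cc1OC` gives > 20000 nM, which is a limit and not a number. Going by the values given here, compound 2 `COc1cccc(/C=C2\CCC/C(=C\c3ccc(OC)c(OC)c3)C2=O)c1` gives 6700 nM, the only true number so far. The next change, leading to compound 3 `COc1ccc(/C=C2\CCC/C(=C\c3ccc(OC)c(OC)c3)C2=O)cc1`, is 4-methoxyphenyl in place of 3-methoxyphenyl on a double-bonded chain carbon bound to a double-bonded ring carbon. Among the compounds with values here, the one measured step at this place, an at least 2.9-fold lower number from compound 1 to compound 2 (0.47 log units; beyond the scatter), replaced a 2-bromophenyl, a different group, and shows only that this place can matter. No shift beyond the scatter is therefore expected in this assay. The estimated change is a 1.1-fold lower number from compound 2 to compound 3 (0.05 log units; within the scatter). For compound 3, the expected value is 6000 nM, with an estimated range of 2200 nM to 18000 nM.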

Compound 3, half-maximal inhibitory concentration: > 20000 nM
Compound 3: a limit, no number; the forecaster's own chance of this, stated with the estimate: 15%; at least 3.3-fold (0.52 log units) between middle value and limit.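

Moving the methoxy group matters at this place: in this assay, 4-methoxyphenyl in place of 3-methoxyphenyl gives an at least 2.9-fold higher number from compound 2 to compound 3 (0.47 log units; beyond the scatter). The two groups hold the same atoms, so this step shows that their arrangement alone can change the result, which the earlier swap of a different group could not show. The full size of this step stays unknown, and the step from compound 1 to compound 3 cannot be read, since both values are limits: the limit of > 20000 nM in this assay, at which 2 of the 3 values shown sit.

Still open, from the compounds shown here alone, is whether a 3-aminophenyl or a 3-carboxyphenyl in place of the 3-methoxyphenyl would match or improve on compound 2.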